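This account rests on a few compounds, and the source may have more. Where it says the series, first, only, none or still open, it means among the compounds named here.

Measured compounds:
compound 1 `CC(C)(O)COc1ccc2c(Oc3ccc(Nc4nccc5[nH]cc(-c6ccccc6)c(=O)c45)cc3F)ccnc2c1`, 2900 nM
compound 2 `CC(C)(O)COc1ccc2c(Oc3ccc(Nc4nccc5[nH]cc(-c6ccc(F)cc6)c(=O)c45)cc3F)ccnc2c1`, 2700 nM

Both numbers come from a functional assay on MKN-45 cells (Homo sapiens) for antiproliferative activity, read by MTT assay, with a stated time of 72 h; a lower number here means a stronger inhibitor, a higher number a weaker inhibitor. Within the data shown here, compound 1 gives 2900 nM and compound 2 gives 2700 nM; the only step in the set, a 1.1-fold lower number from compound 1 to compound 2 (0.03 log units; within the scatter), is within the scatter, so the two compounds cannot be ordered against each other. Compound 2 has the lowest of the two numbers shown, but its only neighbour is within the scatter, so it is not called the stronger inhibitor.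

Compound 3 `COC(C)(C)COc1ccc2c(Oc3ccc(Nc4nccc5[nH]cc(-c6ccc(F)cc6)c(=O)c45)cc3F)ccnc2c1` has not been measured in this assay. It differs from compound 2 in one place: methyl in place of hydrogen on an oxygen on a saturated carbon. Cut one bond further out, the change reads hydroxy to methoxy on the 2-hydroxy-2-methylpropyl chain.

Among the measured compounds shown here, no measured step bears on this change. For the measured compounds named here, the single step available, a 1.1-fold lower number from compound 1 to compound 2 (0.03 log units; within the scatter), concerns a fluoro in place of hydrogen on an aromatic carbon and says nothing about capping the oxygen. The expectation therefore rests on compound 2 alone, and a step of a 1.1-fold higher number from compound 2 to compound 3 (0.05 log units; within the scatter), with no direction beyond the scatter, is expected. Compound 3 is estimated at 3000 nM, with a range from 1200 nM to 8000 nM.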

Compound 3, half-maximal inhibitory concentration: 5500 nM
Estimate against measurement, compound 3: 1.8-fold (0.26 log units) below; the range from low to high includes it.
By their numbers in this assay, from the lowest: compounds 2, 1 and 3 (each within the scatter of the next, the first and the last beyond it).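

In this assay, among these compounds, the hydroxy to methoxy change on the 2-hydroxy-2-methylpropyl chain gives a 2.0-fold higher number from compound 2 to compound 3 (0.31 log units; beyond the scatter) and is the first step to lie beyond the scatter, though only modestly. The chain end therefore responds to a methyl placed on its oxygen, whereas the fluoro change on the aromatic carbon, a 1.1-fold lower number from compound 1 to compound 2 (0.03 log units; within the scatter), left compound 1 and compound 2 unordered. Nothing available accounts for this step, so the note records its direction and size and no more.

On these data alone, whether the step reflects capping of the oxygen in general or the methoxy group in particular stays open, and an amine, a carboxylic acid, an ethoxy group or a longer chain in the same place would help to separate the two readings. As far as these compounds go, it is also open whether the same hydroxy to methoxy change would give a similar step on compound 1, which carries hydrogen in place of the fluoro of compound 2.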